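Side-chain swap on the amino acid carbon: compound 3

This account rests on a few compounds, and the source may have more. Where it says the series, first, only, none or still open, it means among the compounds named here.

Two members of the series have been measured in a functional assay on the whole organism (Tail, strain ICR) with Mus musculus as the target, in the tail flick test, with a stated time of 90 min, at a dose of 25 umol/kg by the oral route; on this read-out higher numbers stand for a stronger effect at the one dose given and lower numbers for a weaker effect. Compound 1 `C[C@H](NC(=O)CN(c1nc(Cl)nc2[nH]cnc12)C1CC1)C(=O)OCc1ccccc1` gives 44.2%. Compound 2 `CC[C@H](C)[C@H](NC(=O)CN(c1nc(Cl)nc2[nH]cnc12)C1CC1)C(=O)O` gives 27.4%, the lower of the two numbers, with compound 1 standing higher by a margin beyond the scatter. Compound 3 `O=C(O)CC[C@H](NC(=O)CN(c1nc(Cl)nc2[nH]cnc12)C1CC1)C(=O)O` carries 2-carboxyethyl in place of sec-butyl on a saturated chain carbon bound to an amide-type nitrogen and a carbonyl carbon. No change of this kind has been measured within the series, so its size is open. The step to compound 3 is expected to be small, in either direction or none beyond the scatter, estimated at a number 2.6 percentage points higher from compound 2 to compound 3 (within the scatter). Compound 3 is therefore expected to give 30%, between 14% and 48%.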

Compound 3, a percentage reported as activity, at one dose (the size of the read-out at that dose, not a potency): 44.7%
Estimate against measurement, compound 3: 14.7 percentage points below; the range from low to high includes it.
By their numbers in this assay, from the lowest: compound 2; then compounds 1 and 3 (each within the scatter of the next).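

In this assay, going by these compounds alone, the side chain on a saturated chain carbon bound to an amide-type nitrogen and a carbonyl carbon matters: 2-carboxyethyl in place of sec-butyl gives a number 17.3 percentage points higher from compound 2 to compound 3 (beyond the scatter), the only step that can be read. A side chain ending in a carboxylic acid therefore does not lose effect at this one dose relative to sec-butyl. No measurement available explains this step.

From the compounds shown here alone, whether the terminal acid or the chain itself carries the step stays open. A primary amide or an amine on the same chain, or a longer chain ending in a carboxylic acid, would separate the two.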